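The source may report more compounds than this note shows. Statements on the series, on what has been measured and on what is new or still open speak of the compounds shown alone.

Compound 2, `Cn1c(-c2ccc(C#N)cc2)cnc1NC(=O)c1ccc(F)cc1`, is an amide in which a 4-fluorophenyl group sits on the carbonyl carbon of a shared core. In a toxicity assay on THP-1 cells (Homo sapiens) for inhibition (a higher number here means that more compound is tolerated, a lower number that less compound is tolerated), compound 2 gives > 50000 nM, which is a limit of the assay rather than a measured number. Compound 1, `Cn1c(-c2ccc(C#N)cc2)cnc1NC(=O)c1ncc[nH]1`, carries a 1H-imidazol-2-yl group on that carbonyl carbon instead, and in this assay compound 1 gives > 100000 nM, again a limit. Compound 3, `COc1ccc2nc(NC(=O)c3ccc(F)cc3)n(C)c2c1`, is built on a different core, and in this assay compound 3 gives > 100000 nM, also a limit. Going by the values given here, the one step between measured compounds, a step that the two limits leave unreadable from compound 1 to compound 2, therefore cannot be read, and the whole picture rests on the limit of > 100000 nM in this assay, at which 2 of the 3 values shown sit, and (the limit of > 50000 nM in this assay, at which 1 of the 3 values shown sits).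

Compound 4, `Cn1c(-c2cccc(Br)c2)cnc1NC(=O)c1ccc(F)cc1`, is made from compound 2 by the change (3-bromophenyl in place of 4-cyanophenyl on an aromatic carbon). Among the compounds with values here, no measured step bears on this change, so the expectation is only that compound 4 behaves as the three measured compounds do, with the step that the limit leaves unreadable from compound 2 to compound 4 expected to lie within the scatter. Compound 4 is estimated at 100000 nM, between 30000 nM and 300000 nM.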

Compound 4, half-maximal cytotoxic concentration: > 50000 nM
Compound 4 ended at the assay's limit; the forecaster's own chance of this, stated with the estimate: 80%; the middle value does not contradict the limit.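

Compound 2 and compound 4 both end at a limit rather than a measured number, so no step can be read from swapping 4-cyanophenyl for 3-bromophenyl. The compounds shown leave open how much of any of them is actually tolerated in this assay, and whether that swap makes any difference.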